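A few compounds are considered here, and "the series" means these few. Any claim that something is new, unique, unknown or untested is made for them only; others in the source may bear on it.

Of the compounds shown here, three sharing one core have been measured. Compound 1 `COc1cc(C2=NN(C(C)=O)C(c3ccc(F)cc3)O2)cc(OC)c1OC` gives -0.4% in a functional assay on BGC-823 cells (Homo sapiens) for antiproliferative activity, read by MTT assay, tested at 1 uM; a higher number here means a stronger effect of the compound at the concentration tested, a lower number a weaker effect. Compound 2 `COc1cc(C2=NN(C(C)=O)C(c3ccc(C(F)(F)F)cc3)O2)cc(OC)c1OC` gives 4.2%, and compound 3 `COc1cc(C2=NN(C(C)=O)C(c3ccccc3F)O2)cc(OC)c1OC` gives 29.6%. Compound 3 thus stands highest of the three numbers: the nearest is compound 2, the step of a number 25.4 percentage points higher from compound 2 to compound 3 (beyond the scatter), and the furthest is compound 1, the step of a number 30 percentage points higher from compound 1 to compound 3 (beyond the scatter), while the step of a number 4.6 percentage points higher from compound 1 to compound 2 (within the scatter) is small.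

Compound 4 `COc1cc(C2=NN(C(C)=O)C(c3ccc(F)c(F)c3)O2)cc(OC)c1OC` is the next compound, not yet measured. Its difference from compound 3 is 3,4-difluorophenyl in place of 2-fluorophenyl on a saturated ring carbon. The two steps that bear on it are those in which the 2-fluorophenyl replaced a 4-fluorophenyl or a 4-(trifluoromethyl)phenyl, each giving a modest rise; here the 2-fluorophenyl leaves and a 3,4-difluorophenyl enters on the same saturated ring carbon, so a modest fall back toward the level of compound 1 is expected in this assay. Compound 4 is therefore expected to give about 8%, in a range from -5% to 25%, an expected step of a number 21.6 percentage points lower from compound 3 to compound 4 (beyond the scatter).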

Compound 4, a percentage reported as inhibition, at one concentration (the size of the read-out at that concentration, not a potency): 18.3%
Compound 4: the middle estimate sits 10.3 percentage points below what was measured, and the stated range covers the measured number.
By their numbers in this assay, from the lowest: compounds 1 and 2 (each within the scatter of the next); then compound 4; then compound 3.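

In this assay, the gain at this saturated ring carbon proves not to belong to the 2-fluorophenyl alone: with fluoro in place of hydrogen on an aromatic carbon of the 4-fluorophenyl, the step is a number 18.7 percentage points higher from compound 1 to compound 4 (beyond the scatter). The 3,4-difluorophenyl also stands clear of the 4-(trifluoromethyl)phenyl, the step being a number 14.1 percentage points higher from compound 2 to compound 4 (beyond the scatter). It does not match the 2-fluorophenyl, however, the step being a number 11.3 percentage points lower from compound 3 to compound 4 (beyond the scatter), so these aryl groups now fall on three separate levels, with compound 1 and compound 2 together on the lowest.

Nothing at hand explains these differences. Going by these compounds, it remains open how this position would respond to a phenyl ring carrying chloro, methoxy, an amine or a carboxylic acid, or to a 2,4-difluorophenyl.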